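The compounds below may be only part of what the source reports. "The series", "measured", "known", "first", "only" and "open" are said of these compounds alone.

Of the compounds shown here, three have been measured in an assay on CHO cells for displacement of a labelled ligand from Substance-P receptor (Homo sapiens); on this read-out lower numbers stand for stronger inhibition and higher numbers for weaker inhibition. Compound 1 `COc1ccccc1N1CCN(C(=O)CCc2c(-c3ccc(Cl)cc3)[nH]c3cccc(Cl)c23)CC1` gives 950 nM, and compound 2 `COc1ccccc1N1CCN(C(=O)CCc2c(-c3ccc(Cl)cc3)[nH]c3cc(Cl)ccc23)CC1` gives 4.9 nM. Compound 3 `Cn1c(-c2ccc(Cl)cc2)c(CCC(=O)N2CCC(O)(Cc3ccccc3)CC2)c2cc(Br)ccc21` gives 0.22 nM, the lowest of the three numbers; its gap to compound 2 and its larger gap to compound 1 both lie beyond the usual scatter of repeated measurements, so compound 3 is the strongest binder of the three. Compound 4 `Cn1c(-c2ccc(Cl)cc2)c(CCC(=O)N2CCC(O)(Cc3ccccc3)CC2)c2cc(-c3ccco3)ccc21` has not yet been measured. It differs from compound 3 in one place: furan-2-yl in place of bromo on an aromatic carbon. Within the data shown here, no measured pair shows what such a change does on the shared core, so any expectation rests on compound 3 alone. The step of a 2.3-fold higher number from compound 3 to compound 4 (0.36 log units; beyond the scatter) is expected to be small, a modest move toward a higher number that may not exceed the scatter. Compound 4 is therefore expected to give about 0.5 nM in this assay, with a likely range from 0.1 nM to 3 nM.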

Compound 4, half-maximal inhibitory concentration: 0.79 nM
Compound 4: middle estimate off by 1.6-fold (0.20 log units), on the low side, within the range that was stated.
By their numbers in this assay, from the lowest: compound 3; then compound 4; then compound 2; then compound 1.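

In this assay, putting furan-2-yl in place of bromo gives a 3.6-fold higher number from compound 3 to compound 4 (0.56 log units; beyond the scatter), a modest loss that is nevertheless beyond the scatter. This position on the six-membered aromatic ring therefore accepts a much larger group that brings its own ring and a hydrogen-bond acceptor, and compound 4 at 0.79 nM remains a strong binder. No measurement here accounts for the size of this step. With only two groups shown at this position, it remains open whether a phenyl ring or thiophen-2-yl would match furan-2-yl, which would indicate whether the furan oxygen matters. From the compounds shown here alone, it also remains open how an amine or a carboxylic acid would fare at the same place on the shared core.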